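The source may report more compounds than this note shows. Statements on the series, on what has been measured and on what is new or still open speak of the compounds shown alone.

Measured so far, in a functional assay on A549 cells (Homo sapiens) for antiproliferative activity, read by MTT assay; on this read-out higher numbers stand for weaker inhibition and lower numbers for stronger inhibition:
- compound 2 `Cn1c(=O)c(=O)n(C2CCCC2)c2nc(N/N=C/c3ccc(Cl)cc3)ncc21` gives 6890 nM
- compound 1 `Cc1cccc(/C=N/Nc2ncc3c(n2)n(C2CCCC2)c(=O)c(=O)n3C)c1` gives 34500 nM
- compound 3 `COc1ccc(/C=N/Nc2ncc3c(n2)n(C2CCCC2)c(=O)c(=O)n3C)cc1` reaches only the assay limit, > 100000 nM

Compound 2 holds the lowest of the two actual numbers; its nearest neighbour is compound 1, with a 5.0-fold lower number from compound 1 to compound 2 (0.70 log units; beyond the scatter). Compound 3 is a limit, not a number (the limit of > 100000 nM in this assay, at which 1 of the 3 values shown sits).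

Compound 4 `Cn1c(=O)c(=O)n(C2CCCC2)c2nc(N/N=C/c3ccccc3F)ncc21` differs from compound 2 by 2-fluorophenyl in place of 4-chlorophenyl on a carbon with a double bond to nitrogen. For the measured compounds named here, the steps that bear on it are a 5.0-fold lower number from compound 1 to compound 2 (0.70 log units; beyond the scatter) and an at least 14-fold higher number from compound 2 to compound 3 (1.16 log units; beyond the scatter): both show that changing the aryl substituent shifts this read-out well beyond the scatter, and neither step carries a 2-fluorophenyl. A modest rise is expected for compound 4, a 2.9-fold higher number from compound 2 to compound 4 (0.46 log units; beyond the scatter). Compound 4 is therefore estimated at 20000 nM in this assay, within 5000 nM to 80000 nM.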

Compound 4, half-maximal inhibitory concentration: 31200 nM
Estimate against measurement, compound 4: 1.6-fold (0.19 log units) below; the range from low to high includes it.
By their numbers in this assay, from the lowest: compound 2; then compounds 4 and 1 (each within the scatter of the next). At a limit, above all of these: compound 3.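

On the carbon with a double bond to nitrogen, 2-fluorophenyl does not reach the level of 4-chlorophenyl, with a 4.5-fold higher number from compound 2 to compound 4 (0.66 log units; beyond the scatter), so compound 2 remains alone at the low end. Against 3-methylphenyl the change gives no distinction, with a 1.1-fold lower number from compound 1 to compound 4 (0.04 log units; within the scatter), so two differently substituted phenyl groups read alike. The step of an at least 3.2-fold lower number from compound 3 to compound 4 (0.50 log units; beyond the scatter) gives only a bound, as compound 3 is a limit, not a number: the limit of > 100000 nM in this assay, at which 1 of the 4 values shown sits.

Open, as far as these compounds go, is whether the halogen or its ring position separates compound 2 from compound 4; a 4-fluorophenyl would address this. Also open, from the compounds shown here alone, is how an amine or a carboxylic acid on the phenyl ring would read.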